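The source may hold more compounds than are shown below. What is called first, only, known or untested is meant among the compounds shown, and "the series" means these compounds.

Measured so far:
compound 1, `CCCS(=O)(=O)Nc1ccc(F)c(C(=O)c2n[nH]c3ncc(-c4ccc(C(C)C)cc4)cc23)c1F`, 17%;
compound 2, `CCCS(=O)(=O)Nc1ccc(F)c(C(=O)c2n[nH]c3ncc(-c4ccc(C(C)(C)C)cc4)cc23)c1F`, 46%;
compound 3, `CCCS(=O)(=O)Nc1ccc(F)c(C(=O)c2n[nH]c3ncc(-c4ccc(S(=O)(=O)NC)cc4)cc23)c1F`, 1.2%.

All three were tested in an assay for binding affinity to dual specificity mitogen-activated protein kinase kinase 4 (Homo sapiens), read by KINOMEscan, tested at 100 nM; on this read-out lower numbers stand for a stronger effect and higher numbers for a weaker effect at the one concentration tested. Compound 3 sits lowest, and its step from compound 1 is a number 15.8 percentage points lower from compound 1 to compound 3 (beyond the scatter). The two cores differ by methylsulfamoyl in place of isopropyl on an aromatic carbon. Compound 4, `CCCS(=O)(=O)Nc1ccc(F)c(C(=O)c2n[nH]c3ncc(-c4ccc(S(=O)(=O)NCC)cc4)cc23)c1F`, has not been measured; it differs from compound 3 by methyl in place of hydrogen on a saturated chain carbon bound to a sulfonamide nitrogen. A change of the same kind, (methyl in place of hydrogen on a saturated chain carbon bound to an aromatic carbon and two saturated chain carbons), gave a number 29 percentage points higher from compound 1 to compound 2 (beyond the scatter), but the place is not the same: there the carbon was bound to an aromatic carbon and two saturated chain carbons, here it is bound to a sulfonamide nitrogen. For compound 4 in this assay a step of a number 4.8 percentage points higher from compound 3 to compound 4 (within the scatter) is expected, a smaller rise because the earlier step of a number 29 percentage points higher from compound 1 to compound 2 (beyond the scatter) stood at a different place. Compound 4 is estimated at 6%, between 0.5% and 25%.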

Compound 4, a percentage reported as activity, at one concentration (the size of the read-out at that concentration, not a potency): 3%
Beside the measured number, compound 4's estimate is 3 percentage points above it; the range from low to high includes it.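

In this assay, extending methylsulfamoyl to ethylsulfamoyl gives a number 1.8 percentage points higher from compound 3 to compound 4 (within the scatter), while ethylsulfamoyl in place of the other groups gives a number 43 percentage points lower from compound 2 to compound 4 (beyond the scatter) and a number 14 percentage points lower from compound 1 to compound 4 (beyond the scatter). Adding a methyl does not have an effect of the same size at both sites, so the earlier step cannot simply be carried over from one core to the other: the same change on two cores in this assay, a number 29 percentage points higher (beyond the scatter) from compound 1 to compound 2 and a number 1.8 percentage points higher (within the scatter) from compound 3 to compound 4, 27.2 percentage points apart, beyond the scatter of two such steps. Among these compounds, this is only one pair of steps at two different places, and it gives neither a rule for other cores nor a reason for the gap.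

The compounds shown leave open whether a longer chain on the sulfonamide nitrogen, such as propyl, would keep the number low. Going by these compounds, how an amine or a carboxylic acid would read in place of methylsulfamoyl also remains open.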